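The source may hold more compounds than are shown below. What is called first, only, known or untested is meant among the compounds shown, and "the series" means these compounds.

Compound 1, `N=c1oc2ccc(Br)cc2cc1C(=O)NCC(O)CO`, was tested in an assay on CHO cells for displacement of a labelled ligand from adenosine receptor A1 (Homo sapiens), read by scintillation counting, with a stated time of 60 min, tested at 10 uM (a lower number here means less inhibition, a higher number more inhibition at the concentration tested (going by the name of the read-out)), where compound 1 gives 11%. Compound 2, `N=c1oc2ccc(Br)cc2cc1C(=O)NCCO`, differs from compound 1 by hydrogen in place of hydroxymethyl on a saturated chain carbon bound to an oxygen on a saturated carbon and a saturated chain carbon, and in this assay compound 2 gives 26%. That single change produced a number 15 percentage points higher from compound 1 to compound 2 (beyond the scatter).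

Compound 3, `COc1cccc2cc(C(=O)NCC(O)CO)c(=O)oc12`, carries a different core; the difference between the core of compound 3 and that of compound 1 is not broken down here. In this assay compound 3 gives 14%, a reading within the scatter of that of compound 1, while the value of compound 2 stands beyond the scatter above it.

Compound 4, `COc1cccc2cc(C(=O)NCCO)c(=O)oc12`, has not yet been measured in this assay. It differs from compound 3 by hydrogen in place of hydroxymethyl on a saturated chain carbon bound to an oxygen on a saturated carbon and a saturated chain carbon, the same change, at the same place, that separates compound 2 from compound 1. Because the same change once gave a number 15 percentage points higher from compound 1 to compound 2 (beyond the scatter), compound 4 is expected to show a step of a number 12 percentage points higher from compound 3 to compound 4 (beyond the scatter). The support is thin: a single earlier pair, on another core, and the scatter of this kind of measurement is wide relative to the numbers involved. On that basis the value of compound 4 in this assay is estimated at 26%, expected to fall somewhere between 10% and 42%.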

Compound 4, a percentage reported as inhibition, at one concentration (the size of the read-out at that concentration, not a potency): 12%
Compound 4: middle estimate off by 14 percentage points, on the high side, and the stated range covers the measured number.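

On the second core, replacing hydroxymethyl with hydrogen on the saturated chain carbon gives a number 2 percentage points lower from compound 3 to compound 4 (within the scatter) in this assay. The rise seen on the core of compound 1 therefore does not carry over to this core, and the two steps differ clearly: the same change on two cores in this assay, a number 15 percentage points higher (beyond the scatter) from compound 1 to compound 2 and a number 2 percentage points lower (within the scatter) from compound 3 to compound 4, 17 percentage points apart, beyond the scatter of two such steps. This shows that, for these two matched pairs, the effect of the change cannot be read from one core and applied to the other, but it does not show which difference between the cores matters or how the change works, and as the numbers are readings at a single concentration, it says nothing about potency.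

The compounds shown leave open how the side chain on the amide nitrogen would read on either core if it ended in an amine or a carboxylic acid, or if it were a longer chain. They also leave open whether a further core would follow the core of compound 1, follow the core of compound 3, or behave like neither, since two pairs cannot establish a rule for the series.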